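The source may report more compounds than this note shows. Statements on the series, on what has been measured and on what is new or still open speak of the compounds shown alone.

Measured in an ADME assay on HepG2 cells (Homo sapiens) for cytotoxicity, read by MTT assay, with a stated time of 48 h; a higher number here means a weaker inhibitor, a lower number a stronger inhibitor:
- compound 1 `C/C(=N/c1ccnc2cc(Cl)ccc12)NCCCCN1CCCCC1`: 9.81 ug/mL
- compound 2 `C/C(=N/c1ccnc2cc(Cl)ccc12)NCCCN1CCCCC1`: 23.3 ug/mL
- compound 3 `CC(C)/C(=N/c1ccnc2cc(Cl)ccc12)NCCCN1CCCCC1`: > 24.2 ug/mL

Compound 3 gives only a limit, > 24.2 ug/mL. Of the two actual numbers, the higher belongs to compound 2 at 23.3 ug/mL, and compound 1 stands lower at 9.81 ug/mL.

The next comparison is compound 4 `CCN(CC)CCCCN/C(C)=N\c1ccnc2cc(Cl)ccc12`, not yet measured in this assay. The change is (diethylamino)methyl in place of piperidin-1-yl on a saturated chain carbon, three bonds along the chain from an amine nitrogen, with (diethylamino)methyl in place of piperidin-1-yl on a saturated chain carbon, three bonds along the chain from an amine nitrogen. The closest guide is a 2.4-fold higher number from compound 1 to compound 2 (0.38 log units; beyond the scatter), which has (piperidin-1-yl)methyl as the group on the lower side. Read in reverse, this step points to a lower number for compound 4, which also carries a methyl link to its terminal amine. Among the measured compounds shown here, no measured step covers the loss of the ring. The step of an at least 1.0-fold higher number from compound 2 to compound 3 (0.01 log units; that floor lies within the scatter) concerns a different place and offers no guidance.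

The expected change is a 1.9-fold lower number from compound 2 to compound 4 (0.29 log units; within the scatter), towards a lower number and of similar size to the step from the reference pair. For compound 4 the estimated value is 12 ug/mL, with an expected range of 6 ug/mL to 24 ug/mL.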

Compound 4, half-maximal inhibitory concentration: 2.68 ug/mL
Estimate against measurement, compound 4: 4.5-fold (0.65 log units) above; the whole stated range lies above it.
By their numbers in this assay, from the lowest: compound 4; then compound 1; then compound 2. At a limit, above all of these: compound 3.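

In this assay, replacing the ring with an open terminal amine lowers the number on the same chain, giving a 3.7-fold lower number from compound 1 to compound 4 (0.56 log units; beyond the scatter). Among the compounds shown here, changing the chain and the terminal group together gives a larger step, an 8.7-fold lower number from compound 2 to compound 4 (0.94 log units; beyond the scatter), so the terminal group itself matters here, which the earlier compounds, all carrying piperidin-1-yl, could not show. No measurement shown here bears on why the open amine gives the lower number.

From the compounds shown here alone, whether this shift follows from opening the ring in general or belongs to diethylamino in particular stays open, and a dimethylamino, pyrrolidin-1-yl or morpholin-4-yl end on the same chain would separate the two. Going by these compounds, how diethylamino behaves on the shorter chain of compound 2, or on a longer chain than that of compound 4, also remains unknown.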